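A few compounds are considered here, and "the series" means these few. Any claim that something is new, unique, unknown or untested is made for them only; others in the source may bear on it.

Compound 1 `Cc1ccc(S(=O)(=O)N[C@@H](CC(=O)NC(C)(C)C)C(=O)NCCNC(=O)c2cccc(C(C)C)c2)cc1` and compound 2 `Cc1ccc(S(=O)(=O)N[C@@H](CC(=O)NC(C)(C)C)C(=O)NCCNC(=O)c2ccc(Cl)cc2)cc1` share one core and differ only in the aromatic group attached to a carbonyl carbon. In an ADME assay on HepG2 cells (Homo sapiens) for cytotoxicity (a higher number here means that more compound is needed for the effect, a lower number that less compound is needed), compound 1 gives > 11000 nM, which is a limit of the assay rather than a number. In this assay compound 2 likewise gives > 11000 nM, again a limit and not a number. The step that the two limits leave unreadable from compound 1 to compound 2 therefore cannot be read, because the limit of > 11000 nM in this assay, at which 2 of the 2 values shown sit, describes where both values sit. Compound 2 thus stands at that limit, with nothing in the data that places it more precisely.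

Compound 3 `Cc1ccc(S(=O)(=O)N[C@@H](CC(=O)NC(C)(C)C)C(=O)NCCNC(=O)c2ccccc2O)cc1` carries the change (2-hydroxyphenyl in place of 4-chlorophenyl on a carbonyl carbon). No measured step bears on this exchange: the only step shown, from compound 1 to compound 2, is unreadable, so it offers neither a size nor a direction for the step from compound 2 to compound 3. The expectation is therefore that compound 3 stays near the limit as well, with the step that the limit leaves unreadable from compound 2 to compound 3 expected to lie within the scatter. Compound 3 is estimated at 20000 nM in this assay, within a range from 8000 nM to 60000 nM.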

Compound 3, half-maximal effective concentration: > 11000 nM
Compound 3 ended at the assay's limit; the forecaster's own chance of this, stated with the estimate: 80%; the middle value lies beyond the limit too.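

Compound 3 in this assay gives > 11000 nM as a limit of the assay, not a number. Compound 1 and compound 2 sit at that same limit, so no step among these three compounds can be read. Still open, from the compounds shown here alone, is how much of each compound is needed for the effect, and whether exchanging the aromatic group changes that amount at all.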